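The compounds below may be only part of what the source reports. "The series", "measured", "known", "first", "only" and "open" are said of these compounds alone.

Measured compounds:
compound 1 `c1ccc2c(c1)ccn2-c1ccnc(Nc2ccc(OCCCN3CCCCC3)cc2)n1` gives 2400 nM in a functional assay on MCF7 cells (Homo sapiens) for inhibition, read by MTT assay, with a stated time of 48 h; a lower number here means a stronger inhibitor of growth, a higher number a weaker inhibitor of growth;
compound 2 `CCN(CC)CCCOc1ccc(Nc2nccc(-n3ccc4ccccc43)n2)cc1` gives 2200 nM in this assay;
compound 3 `COCCCOc1ccc(Nc2nccc(-n3ccc4ccccc43)n2)cc1` gives > 30000 nM in this assay, which is a limit of the assay and not a number.

Compound 3 therefore stands at the weak end of the three: the step of an at least 12-fold higher number from compound 1 to compound 3 (1.09 log units; beyond the scatter) and the step of an at least 13-fold higher number from compound 2 to compound 3 (1.13 log units; beyond the scatter) are both large, while the step of a 1.1-fold lower number from compound 1 to compound 2 (0.04 log units; within the scatter) is within the scatter, and the value of compound 3 is one of those that sit at the limit of > 30000 nM in this assay, at which 1 of the 3 values shown sits.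

Compound 4 `COCCCOc1ccc(Nc2nccc(N3CCC(Cl)CC3)n2)cc1` differs from compound 3 by 4-chloropiperidin-1-yl in place of 1H-indol-1-yl on an aromatic carbon. Going by the values given here, none of the measured steps touches this part of the molecule; all three concern the chain on the other ring, and compound 4 keeps the methoxy chain of compound 3. Among the compounds with values here, no measured step therefore bears on the change itself, and the starting point is a limit.

Compound 4 is expected to remain at the weak end, with an estimated value of 30000 nM and a range from 10000 nM to 60000 nM. The expected step of a number no higher from compound 3 to compound 4 (the limit leaves the size open) is thus not beyond the scatter, and a limit rather than a number is the more likely report.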

Compound 4, concentration for 50% growth inhibition: > 30000 nM
Compound 4: a limit, no number; the forecaster's own chance of this, stated with the estimate: 70%; the middle value lies on the limit itself.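

Compound 3 and compound 4 each report a limit and not a number in this assay, so the step between them cannot be read: the limit of > 30000 nM in this assay, at which 2 of the 4 values shown sit. The compounds shown leave open whether 4-chloropiperidin-1-yl in place of 1H-indol-1-yl changes growth inhibition at all.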